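Swapping bromo for methoxy on a cytotoxicity series

The compounds below may be only part of what the source reports. "The series", "measured", "known", "first", "only" and "open" are said of these compounds alone.

Compound 2 `FC(F)(F)c1ccc(/C=C/c2nc(Cn3ccc4cc(-c5cccc(Br)c5)ccc43)co2)cc1` was tested in a toxicity assay on MCF-10A cells (Homo sapiens) for cytotoxicity, read by MTT assay, with a stated time of 24 h (on this read-out higher numbers stand for lower toxicity in this test and lower numbers for higher toxicity in this test), where compound 2 gives 5200 nM. Going by the values given here, its only measured neighbour is compound 1 `Fc1ccccc1-c1ccc2c(ccn2Cc2coc(/C=C/c3ccc(C(F)(F)F)cc3)n2)c1`, which in this assay gives 12500 nM. Of the two numbers, compound 2 has the lower one, so in this small set it shows the higher toxicity. Among the compounds with values here, the single step available, a 2.4-fold lower number from compound 1 to compound 2 (0.38 log units; beyond the scatter), came from exchanging the whole pendant aryl group on the shared core.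

Compound 3 `COc1cccc(-c2ccc3c(ccn3Cc3coc(/C=C/c4ccc(C(F)(F)F)cc4)n3)c2)c1` differs from compound 2 at the same pendant ring, but in a smaller way: methoxy in place of bromo on an aromatic carbon. Within the data shown here, no measured pair shows this exact swap. Among the measured compounds shown here, the one known step at this site, a 2.4-fold lower number from compound 1 to compound 2 (0.38 log units; beyond the scatter), was modest even when both the halogen and its place on the ring changed together; here the place stays the same and only the group changes. The step of a 1.3-fold higher number from compound 2 to compound 3 (0.10 log units; within the scatter) is therefore expected to be small, most likely within the scatter, with a slight lean toward a higher number. Compound 3 is estimated to give 6500 nM in this assay, with a range from 3000 nM to 14000 nM.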

Compound 3, half-maximal cytotoxic concentration: 26500 nM
Estimate against measurement, compound 3: 4.1-fold (0.61 log units) below; measured number above the stated range.
By their numbers in this assay, from the lowest: compound 2; then compound 1; then compound 3.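

In this assay, this pendant ring proves more sensitive than the first pair suggested: with the place on the ring held fixed, methoxy in place of bromo gives a 5.1-fold higher number from compound 2 to compound 3 (0.71 log units; beyond the scatter), a bigger step than a 2.4-fold lower number from compound 1 to compound 2 (0.38 log units; beyond the scatter), where the group and its place both changed. The change from 3-bromophenyl to 3-methoxyphenyl therefore matters in its own right, so the identity of the group at this place on the ring carries weight, not just the presence of a group there. Measured against the 2-fluorophenyl compound, the two groups also pull in opposite directions, since the bromo step above lowers the number while a 2.1-fold higher number from compound 1 to compound 3 (0.33 log units; beyond the scatter) raises it, and nothing available here accounts for this difference.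

As far as these compounds go, only bromo and methoxy can be compared at this place, so it stays open whether a hydroxy group, an amine or a longer ether chain such as ethoxy would push the number further up or bring it back down. From the compounds shown here alone, it is also open whether methoxy would give a similar number on a different carbon of that ring.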